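Swapping the aryl amide: from pyridine to methoxyphenyl

A few compounds are considered here, and "the series" means these few. Any claim that something is new, unique, unknown or untested is made for them only; others in the source may bear on it.

Measured compounds and their values:
Compound 1 `Cc1ccc(S(=O)(=O)NCc2ccc(CNC(=O)c3ccc(F)cc3)cc2)cc1`: 75%
Compound 2 `O=C(NCc1ccc(CNS(=O)(=O)c2ccccc2)cc1)c1ccc(F)cc1`: 40%
Compound 3 `O=C(NCc1ccc(CNS(=O)(=O)c2ccccc2)cc1)c1cccnc1`: 53%

All three compounds were tested in a functional assay on the whole organism for inhibition, with Mus musculus as the target, with stated times of 30 min and 2 h, at a dose of 10 mg/kg by the intraperitoneal route; on this read-out lower numbers stand for less inhibition and higher numbers for more inhibition at the one dose given (going by the name of the read-out). Compound 3 stands second of the three: compound 1 lies above it, and compound 2 lies below it, each beyond the scatter of the assay.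

Compound 4 `COc1ccccc1C(=O)NCc1ccc(CNS(=O)(=O)c2ccccc2)cc1` has not yet been measured. It differs from compound 3 in one place: 2-methoxyphenyl in place of pyridin-3-yl on a carbonyl carbon. The position touched is the same one changed between compound 2 and compound 3, where a number 13 percentage points higher from compound 2 to compound 3 (beyond the scatter). The other measured step, a number 35 percentage points lower from compound 1 to compound 2 (beyond the scatter), concerns a different position and does not bear on this change. Within the data shown here, only one step at this position is known, and it was modest, so a step of modest size in either direction, or none beyond the scatter, is expected here.

For compound 4 in this assay the estimate is 47%, with a range from 27% to 67%. The estimated step from compound 3 to compound 4 is therefore a number 6 percentage points lower from compound 3 to compound 4 (within the scatter), expected to stay within the scatter.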

Compound 4, a percentage reported as inhibition, in the whole organism at one dose (the size of the read-out at that dose, not a potency): "not active" (no number reported)
Compound 4 has no reported number here; the estimate stays without a comparison.
By their numbers in this assay, from the lowest: compound 2; then compound 3; then compound 1.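

Among these compounds, compound 4 is reported in this assay only as "not active", without a number, so no step from compound 3 to compound 4 can be read. From the compounds shown here alone, how much 2-methoxyphenyl in place of pyridin-3-yl changes inhibition stays open, and no available evidence bears on this result.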